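Fluorophenyl for Methoxyphenyl on a Piperazine Succinimide

This account rests on a few compounds, and the source may have more. Where it says the series, first, only, none or still open, it means among the compounds named here.

Compound 1 `COc1cccc(N2CCN(C(=O)C(C)N3C(=O)CCC3=O)CC2)c1` was tested in a functional assay on the whole organism (strain Swiss) with Mus musculus as the target, in the maximal electroshock model, with a stated time of 2 h, at a dose of 300 mg/kg by the intraperitoneal route (on this read-out lower numbers stand for a weaker effect and higher numbers for a stronger effect at the one dose given), and gave 0%. Compound 2 `CCC(C(=O)N1CCOCC1)N1C(=O)CCC1=O` gave 0% in this assay, level with compound 1 within the scatter, so the two together stand lowest of the three numbers. Compound 3 `CCC(C(=O)N1CCN(c2ccccc2)CC1)N1C(=O)CCC1=O` gave 25% in this assay, a number beyond the scatter above compound 1. Compound 4 `CC(C(=O)N1CCN(c2ccc(F)cc2)CC1)N1C(=O)CCC1=O` has not been measured; it differs from compound 1 in one place, (4-fluorophenyl in place of 3-methoxyphenyl on an amine nitrogen in a ring). Among the compounds with values here, no step between two measured compounds isolates this change. The step from compound 1 to compound 4 is expected to be small and upward, about a number 15 percentage points higher from compound 1 to compound 4 (beyond the scatter), close to the scatter. Compound 4 is estimated to give 15% in this assay, within a range from 0% to 40%.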

Compound 4, a percentage reported as activity, at one dose (the size of the read-out at that dose, not a potency): 50%
Beside the measured number, compound 4's estimate is 35 percentage points below it; the measured number lies above the stated range.
By their numbers in this assay, from the lowest: compounds 1 and 2 (each within the scatter of the next); then compound 3; then compound 4.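

In this assay, putting 4-fluorophenyl in place of 3-methoxyphenyl on the amine nitrogen in the ring gives a number 50 percentage points higher from compound 1 to compound 4 (beyond the scatter), a large step. Within the data shown here, this is the first sign that the aryl group at this position can decide between no effect and a clear one at the single dose given. Nothing available explains the step.

Going by these compounds, whether the rise follows the fluorine or the ring position of the substituent stays open: a 4-methoxyphenyl or a 3-fluorophenyl on this nitrogen would separate the two. On these data alone, how a 4-chlorophenyl would read there is also open.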